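This account rests on a few compounds, and the source may have more. Where it says the series, first, only, none or still open, it means among the compounds named here.

Measured compounds:
- compound 1, `COc1ccc(NC(=O)c2cc3ccccc3oc2=O)cc1`, gives 820 nM in an in vitro assay on BTI-TN-5B1-4 cells for inhibition of Amine oxidase [flavin-containing] B (Homo sapiens), read by fluorescence; on this read-out higher numbers stand for weaker inhibition and lower numbers for stronger inhibition
- compound 2, `COc1ccc(NC(=O)c2cc3ccccc3oc2=O)cc1OC`, gives 860 nM in this assay

In this assay compound 2 and compound 1 give numbers that lie within the scatter of each other, so neither stands apart from the other. Among the compounds with values here, the single measured step, a 1.0-fold higher number from compound 1 to compound 2 (0.02 log units; within the scatter), describes a methoxy added on an aromatic carbon and stays within the scatter. Compound 3, `COc1ccc(NC(=O)c2cc3ccc(OCc4ccc(F)cc4)cc3oc2=O)cc1OC`, differs from compound 2 by (4-fluorobenzyl)oxy in place of hydrogen on an aromatic carbon. Within the data shown here, no measured step touches this part of the shared core, and none involves a group of this kind, so the one known step offers no direct guidance. With no evidence pointing either way, compound 3 is expected to give a number close to that of compound 2, the step of a 1.1-fold lower number from compound 2 to compound 3 (0.03 log units; within the scatter) being the expected change, with a wide range to reflect the uncertainty. Compound 3 is therefore estimated at 800 nM, expected to fall between 150 nM and 4000 nM.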

Compound 3, half-maximal inhibitory concentration: 2870 nM
Beside the measured number, compound 3's estimate is 3.6-fold (0.55 log units) below it; the measured number falls inside the stated range.
By their numbers in this assay, from the lowest: compounds 1 and 2 (each within the scatter of the next); then compound 3.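

In this assay, within the data shown here, putting (4-fluorobenzyl)oxy on this aromatic carbon of the fused two-ring system gives a 3.3-fold higher number from compound 2 to compound 3 (0.52 log units; beyond the scatter), the first step to lie beyond the scatter, and it runs toward weaker inhibition. The earlier step, a 1.0-fold higher number from compound 1 to compound 2 (0.02 log units; within the scatter), placed a methoxy elsewhere in the molecule and stayed within the scatter, so the series now holds a change that does move the number, though only modestly. Nothing measured here explains this shift.

The compounds shown leave open whether a small group on this carbon, such as a hydroxyl or a methoxy, would move the number at all. They also leave open whether the fluorine plays any part, which plain benzyloxy at the same place would test.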